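The source may hold more compounds than are shown below. What is called first, only, known or untested is meant among the compounds shown, and "the series" means these compounds.

Measured so far:
Compound 1, `O=C(Nc1cnn(-c2ccccc2)c1)c1cccc(NS(=O)(=O)c2ccccc2)c1`: 10100 nM
Compound 2, `O=C(Nc1cnn(-c2ccccc2)c1)c1cccc(NS(=O)(=O)c2ccc(Cl)cc2)c1`: 8540 nM

In a functional assay on HepG2 cells (Homo sapiens) for inhibition, read by MTT assay, with a stated time of 48 h (a lower number here means a stronger inhibitor, a higher number a weaker inhibitor), compound 2 gives 8540 nM, and compound 1 gives 10100 nM in this assay. These are the only two numbers shown, and they lie close together: the step of a 1.2-fold lower number from compound 1 to compound 2 (0.07 log units; within the scatter) is within the scatter, so neither compound can be called the stronger one.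

Compound 3, `COc1cccc(-n2cc(NC(=O)c3cccc(NS(=O)(=O)c4ccc(Cl)cc4)c3)cn2)c1`, has not yet been measured in this assay. It differs from compound 2 in one place: methoxy in place of hydrogen on an aromatic carbon. Within the data shown here, this change sits on the phenyl that hangs from the shared core, not on the sulfonyl phenyl where the one measured step was made. That step, chloro in place of hydrogen, gave a 1.2-fold lower number from compound 1 to compound 2 (0.07 log units; within the scatter), a change within the scatter. Among the measured compounds shown here, no measured step tests a methoxy group, and none tests the ring that is changed here, so the expectation rests on the one small step and on the shared core.

On that basis compound 3 is expected to stay close to compound 2, with an estimated step of a 1.1-fold lower number from compound 2 to compound 3 (0.03 log units; within the scatter) in this assay. The estimate for compound 3 is 8000 nM, with a range from 3000 nM to 25000 nM.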

Compound 3, half-maximal inhibitory concentration: 19600 nM
Beside the measured number, compound 3's estimate is 2.5-fold (0.39 log units) below it, and the stated range covers the measured number.
By their numbers in this assay, from the lowest: compounds 2, 1 and 3 (each within the scatter of the next, the first and the last beyond it).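

In this assay, the change from phenyl to 3-methoxyphenyl gives the only step shown that lies beyond the scatter (a modest one: a 2.3-fold higher number from compound 2 to compound 3 (0.36 log units; beyond the scatter)), and it points toward a weaker inhibitor. Among these compounds, the step on the sulfonyl phenyl (a 1.2-fold lower number from compound 1 to compound 2 (0.07 log units; within the scatter)) stayed within the scatter, so this result is the first sign that the number can respond to a single change, here on the phenyl that hangs from the shared core. Still, it is one methoxy group at one place on that ring, and nothing available bears on why the number moved.

The compounds shown leave open whether this ring tolerates only a hydrogen at this position or whether the loss is specific to methoxy, since no other group, such as an amine, a carboxylic acid or a longer ether chain, appears there. They also leave open whether a methoxy group on another carbon of this ring, or on the same ring without the chloro group on the sulfonyl phenyl, would shift the number in the same way.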